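The compounds below may be only part of what the source reports. "The series", "measured", "known", "first", "only" and "open" are said of these compounds alone.

Of the compounds shown here, two sharing one core have been measured in a functional assay on Hs68 cells (Homo sapiens) for cytotoxicity; a higher number here means that more compound is tolerated, a lower number that less compound is tolerated: compound 1 (`CC(C)Oc1ccccc1CNC(=O)c1ccc2cncc(Br)c2n1`) gives 9 ug/mL, and compound 2 (`CC(C)Oc1ccccc1CNC(=O)c1ccc2cncc(Cl)c2n1`) gives 6 ug/mL. Among the compounds with values here, compound 2 therefore stands within the scatter of compound 1, its only measured neighbour. The next compound is compound 3 (`C=Cc1cncc2ccc(C(=O)NCc3ccccc3OC(C)C)nc12`), which differs from compound 2 as follows: vinyl in place of chloro on an aromatic carbon. In short, vinyl replaces chloro on an aromatic carbon. Within the data shown here, the single measured step bearing on this swap is a 1.5-fold lower number from compound 1 to compound 2 (0.18 log units; within the scatter), a change on that same carbon that did not exceed the scatter. Among the measured compounds shown here, no measured compound carries vinyl, so this one step is thin guidance, and no step beyond the scatter is expected in this assay. The expected step is a 1.2-fold higher number from compound 2 to compound 3 (0.07 log units; within the scatter). Compound 3 is estimated at 7 ug/mL, with an expected range from 3 ug/mL to 16 ug/mL.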

Compound 3, half-maximal cytotoxic concentration: 17 ug/mL
Compound 3: middle estimate off by 2.4-fold (0.39 log units), on the low side, and the stated range ends below it.
By their numbers in this assay, from the lowest: compounds 2, 1 and 3 (each within the scatter of the next, the first and the last beyond it).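

In this assay, this aromatic carbon, two atoms from the ring nitrogen, now shows a modest change beyond the scatter: vinyl in place of chloro gives a clear separation (a 2.8-fold higher number from compound 2 to compound 3 (0.45 log units; beyond the scatter)), which the exchange of one halogen for the other had not shown. Vinyl in place of bromo stays within the scatter (a 1.9-fold higher number from compound 1 to compound 3 (0.28 log units; within the scatter)), so the position separates vinyl from chloro but not from bromo, and the change cannot be read as a general gain for vinyl over halogens. No measurement available here accounts for the step from chloro to vinyl. The compounds shown leave open whether the double bond matters or only the two carbons, which an ethyl group on this carbon would address. They also leave open how an amine or a longer chain would fare at this position.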